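Replacing 3-bromopropyl with cyclohexyl on the shared core

The compounds below may be only part of what the source reports. "The series", "measured", "known", "first", "only" and "open" are said of these compounds alone.

In a functional assay on A549 cells (Homo sapiens) for cytotoxicity, read by MTT assay, with a stated time of 48 h (on this read-out lower numbers stand for stronger inhibition and higher numbers for weaker inhibition), compound 1 `C=C1C(=O)O[C@H]2CC3=C[C@H](C/C(C)=C/[C@@H](OC(=O)c4ccc([N+](=O)[O-])cc4)[C@H]12)OC3=O` gives > 10000 nM, which is a limit of the assay. For the measured compounds named here, compound 2 `C=C1C(=O)O[C@H]2CC3=C[C@H](C/C(C)=C/[C@@H](OC(=O)/C=C/c4ccccc4)[C@H]12)OC3=O` gives 4800 nM, the only true number so far. Compound 3 `C=C1C(=O)O[C@H]2CC3=C[C@H](C/C(C)=C/[C@@H](OC(=O)CCCCBr)[C@H]12)OC3=O` gives > 10000 nM, also a limit. Compound 4 `C=C1C(=O)O[C@H]2CC3=C[C@H](C/C(C)=C/[C@@H](OC(=O)CC4CCCCC4)[C@H]12)OC3=O` differs from it as follows: cyclohexyl in place of 3-bromopropyl on a saturated chain carbon bound to a carbonyl carbon. The bearing steps all change the group on the carbonyl carbon: an at least 2.0-fold higher number from compound 2 to compound 3 (0.31 log units; beyond the scatter), an at least 2.0-fold lower number from compound 1 to compound 2 (0.31 log units; beyond the scatter) and a step that the two limits leave unreadable from compound 1 to compound 3. Only 2-phenylethenyl has left the limit, and compound 4 does not carry it, so only a small move towards a lower number is expected in this assay: the expected change is an at least 1.1-fold lower number from compound 3 to compound 4 (0.04 log units; that floor lies within the scatter). Compound 4 is estimated at 9000 nM, with an expected range of 4000 nM to 20000 nM.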

Compound 4, half-maximal inhibitory concentration: 6900 nM
Beside the measured number, compound 4's estimate is 1.3-fold (0.12 log units) above it; low and high end bracket the measured number.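

In this assay, a second group on the carbonyl carbon, cyclohexylmethyl, gives a true number and not a limit, so 2-phenylethenyl is no longer the only such group in a set where limits are common: the limit of > 10000 nM in this assay, at which 2 of the 4 values shown sit.

Measured against the limits, the steps are an at least 1.4-fold lower number from compound 3 to compound 4 (0.16 log units; that floor lies within the scatter) and an at least 1.4-fold lower number from compound 1 to compound 4 (0.16 log units; that floor lies within the scatter), and both are floors only. The step between the two true numbers is a 1.4-fold higher number from compound 2 to compound 4 (0.16 log units; within the scatter), so cyclohexylmethyl and 2-phenylethenyl cannot be told apart here.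

From the compounds shown here alone, it remains open how a 2-phenylethyl group would read at this position. The same holds for a chain ending in an amine.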